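The compounds below may be only part of what the source reports. "The series", "measured", "known", "first", "only" and "open" are said of these compounds alone.

Measured in a functional assay on HCT-116 cells (Homo sapiens) for inhibition; on this read-out lower numbers stand for stronger inhibition and higher numbers for weaker inhibition:
- compound 1 `CCNC(=O)c1noc(-c2cc(C(C)C)c(O)cc2O)c1-c1cc(COCC(=O)O)no1` gives "not determined" (no result reported)
- compound 2 `CCCNCc1cc(-c2c(C(=O)NCC)noc2-c2cc(C(C)C)c(O)cc2O)on1` gives 117 nM
- compound 3 `CCNC(=O)c1noc(-c2cc(C(C)C)c(O)cc2O)c1-c1cc(CN2CCN(C)CC2)no1` gives 340 nM

Compound 3 has the higher of the two numbers available, and compound 2 is the nearest value. Compound 4 `CCNC(=O)c1noc(-c2cc(C(C)C)c(O)cc2O)c1-c1cc(C(=O)NC)no1` differs from compound 3 by one change, (methylcarbamoyl in place of (4-methylpiperazin-1-yl)methyl on an aromatic carbon), with methylcarbamoyl in place of (4-methylpiperazin-1-yl)methyl on an aromatic carbon. Among the measured compounds shown here, only one measured step bears on this. It is a 2.9-fold higher number from compound 2 to compound 3 (0.46 log units; beyond the scatter), a modest change made when 4-methylpiperazin-1-yl replaced propylamino on the saturated chain carbon. For the measured compounds named here, that step is only a loose guide, since no measured compound carries methylcarbamoyl. Compound 1 also changes this part of the structure, but it offers no number for comparison. With compound 3 at 340 nM and compound 2 lower at 117 nM, a modest move toward a lower number seems the likeliest outcome, although the direction remains uncertain. The expected change is a 2.3-fold lower number from compound 3 to compound 4 (0.36 log units; beyond the scatter) in this assay. For compound 4 the estimated value is 150 nM, with an expected range from 40 nM to 600 nM.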

Compound 4, half-maximal inhibitory concentration: 124 nM
Compound 4: the middle estimate sits 1.2-fold (0.08 log units) above what was measured; the range from low to high includes it.
By their numbers in this assay, from the lowest: compounds 2 and 4 (each within the scatter of the next); then compound 3.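

In this assay, putting methylcarbamoyl, which has no ring, in place of (4-methylpiperazin-1-yl)methyl on this aromatic carbon gives a 2.7-fold lower number from compound 3 to compound 4 (0.44 log units; beyond the scatter), so the position can hold a group with a carbonyl and without any amine while the number still falls. Methylcarbamoyl in place of (propylamino)methyl gives a 1.1-fold higher number from compound 2 to compound 4 (0.03 log units; within the scatter), so these two quite different groups cannot be told apart here, and among these compounds an amine in this side group is not required to reach this level of inhibition. No separate measurement is available to explain these differences.

From the compounds shown here alone, it remains open whether the amide hydrogen matters, which dimethylcarbamoyl at this position would test. Also open, going by these compounds, is how a longer chain, as in propylcarbamoyl, or a carboxylic acid directly on this carbon would compare.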